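Oxazolyl for Pyrimidinyl on a Sulfonamide Nitrogen

A few compounds are considered here, and "the series" means these few. Any claim that something is new, unique, unknown or untested is made for them only; others in the source may bear on it.

Measured so far in a functional assay on B16-F10 cells (Mus musculus) for cytotoxicity, read by CCK-8 assay, with a stated time of 48 h; a higher number here means a weaker inhibitor, a lower number a stronger inhibitor:
Compound 1, `Cc1cc(C)nc(NS(=O)(=O)c2ccc(/N=C/c3c(Cl)c4cc(C(C)(C)C)cc(C(C)(C)C)c4oc3=O)cc2)n1`, gives 220 nM.
Compound 2, `Cc1cc(NS(=O)(=O)c2ccc(/N=C/c3c(Cl)c4cc(C(C)(C)C)cc(C(C)(C)C)c4oc3=O)cc2)no1`, gives 240 nM.
Compound 3, `Cc1ccc2oc(=O)c(/C=N/c3ccc(S(=O)(=O)Nc4nc(C)cc(C)n4)cc3)c(Cl)c2c1`, gives 300 nM.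

Compounds 1 and 2 share one core, while compound 3 carries another; the difference between the two cores is not broken down here. Compound 4, `Cc1ccc2oc(=O)c(/C=N/c3ccc(S(=O)(=O)Nc4cc(C)on4)cc3)c(Cl)c2c1`, has not yet been measured.

The change from compound 1 to compound 2 is 5-methyl-1,2-oxazol-3-yl in place of 4,6-dimethylpyrimidin-2-yl on a sulfonamide nitrogen. In this assay it made a 1.1-fold higher number from compound 1 to compound 2 (0.04 log units; within the scatter). The change from compound 3 to compound 4 is 5-methyl-1,2-oxazol-3-yl in place of 4,6-dimethylpyrimidin-2-yl on a sulfonamide nitrogen. The surroundings of the place are described in the same words for both pairs, so this is the same change at the same kind of place, only on a different core. The values of compound 3 and compound 2 lie within the scatter of each other, and so do those of compound 3 and compound 1.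

Going by the values given here, compound 4 is expected to show a 1.1-fold higher number from compound 3 to compound 4 (0.04 log units; within the scatter) because the one measured example of this change gave a 1.1-fold higher number from compound 1 to compound 2 (0.04 log units; within the scatter). That rests on a single pair, so the expectation is loose. Compound 4 is estimated at 330 nM, with a plausible range from 150 nM to 720 nM.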

Compound 4, half-maximal inhibitory concentration: 250 nM
Beside the measured number, compound 4's estimate is 1.3-fold (0.12 log units) above it; measured number inside the range.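

In this assay, putting 5-methyl-1,2-oxazol-3-yl in place of 4,6-dimethylpyrimidin-2-yl on a sulfonamide nitrogen gave a 1.2-fold lower number from compound 3 to compound 4 (0.08 log units; within the scatter). Set beside the earlier pair, the two cores do not distinguish the outcome of this change: the same change on two cores in this assay, a 1.1-fold higher number (0.04 log units; within the scatter) from compound 1 to compound 2 and a 1.2-fold lower number (0.08 log units; within the scatter) from compound 3 to compound 4, 1.3-fold (0.12 log units) apart, within the scatter of two such steps. This shows that on both cores shown the exchange stayed within the scatter, but with so few pairs and neither step beyond the scatter, it gives no direction for the change and does not show that the same result would hold on other cores or in other assays.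

The compounds shown leave open whether a different group on the sulfonamide nitrogen, such as a plain phenyl ring or an open alkyl chain, would shift the number beyond the scatter. They also leave open what would follow if the chlorine on the core gave way to a methoxy group or an amine.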